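A few compounds are considered here, and "the series" means these few. Any claim that something is new, unique, unknown or untested is made for them only; others in the source may bear on it.

Measured compounds in this series:
- compound 1 `CCCCNc1nc(N)nc(C)c1CCCN1CCN(C)CC1`: 179 nM
- compound 2 `CCCCNc1nc(N)nc(C)c1CCCN1CCCCC1`: 133 nM
- compound 3 `CCCCNc1nc(N)nc(C)c1CC`: 1660 nM

In an assay on HEK293 cells for agonist activity at Toll-like receptor 8 (Homo sapiens), read by spectrophotometry (on this read-out lower numbers stand for an effect already at smaller amounts and higher numbers for an effect only at larger amounts of compound), compound 3 gives the highest number of the three measured compounds. Its nearest neighbour is compound 1, and the gap to compound 2 is wider still; both gaps lie beyond the scatter.

Compound 4 `CCCCNc1nc(N)nc(C)c1CCCC` has not yet been measured. It differs from compound 3 by ethyl in place of hydrogen on a saturated chain carbon, two bonds along the chain from an aromatic carbon, so the short chain of compound 3 is lengthened without adding a ring or a hydrogen-bond acceptor.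

Among the measured compounds shown here, two measured steps bear on this. a 12-fold higher number from compound 2 to compound 3 (1.10 log units; beyond the scatter) shows that removing the whole (piperidin-1-yl)methyl group at this very position costs much. a 1.3-fold lower number from compound 1 to compound 2 (0.13 log units; within the scatter) shows that exchanging one ring amine for another at the chain end changes little. The large step therefore coincides with loss of the amine-bearing group, and a plain ethyl extension restores none of that. Compound 4 is thus expected to give a number close to that of compound 3, with at most a modest step in this assay, as a 1.5-fold lower number from compound 3 to compound 4 (0.18 log units; within the scatter) expresses. The estimate for compound 4 is 1100 nM, with a range from 450 nM to 2700 nM.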

Compound 4, half-maximal effective concentration: 780 nM
Beside the measured number, compound 4's estimate is 1.4-fold (0.15 log units) above it; the measured number falls inside the stated range.
By their numbers in this assay, from the lowest: compounds 2 and 1 (each within the scatter of the next); then compound 4; then compound 3.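

In this assay, ethyl in place of hydrogen on this saturated chain carbon has a small but readable effect: a 2.1-fold lower number from compound 3 to compound 4 (0.33 log units; beyond the scatter) lies beyond the scatter, so carbon chain alone recovers part of the distance from the ring-bearing compounds. Chain alone does not close that distance, however: a 5.9-fold higher number from compound 2 to compound 4 (0.77 log units; beyond the scatter) and a 4.4-fold higher number from compound 1 to compound 4 (0.64 log units; beyond the scatter) both lie beyond the scatter, so with chain length held the same, piperidin-1-yl and 4-methylpiperazin-1-yl each give a lower number than methyl at the chain end, and the large loss seen earlier splits into a smaller part tied to the chain and a larger part tied to the ring amine. No supporting data bear on why either part arises.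

Open, from the compounds shown here alone, is whether a longer chain such as pentyl or hexyl at this place lowers the number further or reverses the small gain. Equally open, going by these compounds, is whether a chain of this length ending in a primary amine or a carboxylic acid comes close to the ring amines, which would show how much of the ring itself is needed.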